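The source may hold more compounds than are shown below. What is called first, only, known or untested is meant among the compounds shown, and "the series" means these compounds.

Compound 1 `[O-][n+]1nc(NC2CCCCC2)[n+]([O-])c2ccccc21` gives 9500 nM in a functional assay on HepG2 cells (Homo sapiens) for cytotoxicity, read by MTT assay, with a stated time of 48 h; on this read-out lower numbers stand for stronger inhibition and higher numbers for weaker inhibition.
Compound 2 `[O-][n+]1nc(NC2CC2)[n+]([O-])c2ccccc21` gives 13300 nM in this assay.
Compound 3 `CCN(CC)c1n[n+]([O-])c2ccccc2[n+]1[O-]` gives only a limit of the assay, > 107000 nM in this assay.

Among the two numbers, compound 2 and compound 1 lie within the scatter of each other; the value of compound 3 is a limit (the limit of > 107000 nM in this assay, at which 1 of the 3 values shown sits). Compound 4 `[O-][n+]1nc(Nc2ccccc2)[n+]([O-])c2ccccc21` differs from compound 2 in one place: phenyl in place of cyclopropyl on a nitrogen on an aromatic ring. Within the data shown here, two measured steps touch this change. The ring on the nitrogen on the aromatic ring was already varied, and a 1.4-fold higher number from compound 1 to compound 2 (0.15 log units; within the scatter) shows that the size of that ring made no difference beyond the scatter. The other step, an at least 8.0-fold higher number from compound 2 to compound 3 (0.90 log units; beyond the scatter), concerns a diethylamino in place of a cyclopropylamino and so removes the nitrogen-bound hydrogen, which compound 4 keeps. The nearer step points to little movement. Compound 4 is therefore expected to stay close to compound 2 in this assay, with a 1.2-fold lower number from compound 2 to compound 4 (0.08 log units; within the scatter) as the expected step. The estimate for compound 4 is 11000 nM, within 4000 nM to 35000 nM.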

Compound 4, half-maximal inhibitory concentration: 15000 nM
The estimate for compound 4 lay 1.4-fold (0.13 log units) below the measured number, and the stated range covers the measured number.
By their numbers in this assay, from the lowest: compounds 1, 2 and 4 (each within the scatter of the next). At a limit, above all of these: compound 3.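

In this assay, replacing the non-aromatic rings with an aromatic one on this nitrogen produces no change beyond the scatter: the steps are a 1.1-fold higher number from compound 2 to compound 4 (0.05 log units; within the scatter) and a 1.6-fold higher number from compound 1 to compound 4 (0.20 log units; within the scatter). The earlier compounds shown here had varied only the size of a non-aromatic ring, whereas compound 4 shows that the phenyl ring fits the same flat picture, so among compounds 1, 2 and 4 neither ring size nor aromatic character separates the numbers. Nothing measured here gives a reason for this flatness.

From the compounds shown here alone, it remains open what a phenyl carrying a methoxy group or a chlorine atom, a benzyl group, or an open chain ending in an amine or a carboxylic acid would give on this nitrogen. Compound 3 is the only compound shown without the nitrogen-bound hydrogen, so a piperidine in that place would be needed to tell whether losing that hydrogen or the diethyl groups themselves matter.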